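Selenoquinoline propargyl esters: cinnamate to terephthalate half-ester

The compounds below may be only part of what the source reports. "The series", "measured", "known", "first", "only" and "open" are said of these compounds alone.

Measured so far:
- Compound 1, `C#CCSc1cnc2ccccc2c1[Se]CC#CCCl`: 0.4 ug/mL
- Compound 2, `CSc1cnc2ccccc2c1[Se]CC#CCOC(=O)/C=C/c1ccccc1`: 4.3 ug/mL

Among the compounds with values here, in a functional assay on T47D cells (Homo sapiens) for antiproliferative activity, with a stated time of 72 h (a lower number here means a stronger inhibitor, a higher number a weaker inhibitor), compound 2 holds the highest of the two numbers; its only neighbour, compound 1, sits well below it, beyond the scatter. Compound 3, `CSc1cnc2ccccc2c1[Se]CC#CCOC(=O)c1ccc(C(=O)O)cc1`, carries the change (4-carboxyphenyl in place of 2-phenylethenyl on a carbonyl carbon). Within the data shown here, no measured pair isolates this change, so the step from compound 2 to compound 3 has no direct precedent in the set. The expected step is a 1.9-fold higher number from compound 2 to compound 3 (0.27 log units; within the scatter), a modest move toward a higher number. Compound 3 is estimated at 8 ug/mL, within 3 ug/mL to 20 ug/mL.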

Compound 3, concentration for 50% inhibition: 3.2 ug/mL
Beside the measured number, compound 3's estimate is 2.5-fold (0.40 log units) above it, and the stated range covers the measured number.
By their numbers in this assay, from the lowest: compound 1; then compounds 3 and 2 (each within the scatter of the next).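

On a carbonyl carbon, 4-carboxyphenyl in place of 2-phenylethenyl gives a 1.3-fold lower number from compound 2 to compound 3 (0.13 log units; within the scatter) in this assay. Within the data shown here, this is the first single-place step, and it shows that this position accepts the carboxyl-bearing ring with no readable shift in the number. No supporting measurement offers an explanation for this flat step.

Going by these compounds, whether an amide or a methyl ester in place of the carboxylic acid would stay level with compound 3 remains open. Compound 1 differs from both esters in more than one place, so its gap to them cannot be assigned to any single change.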